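This account rests on a few compounds, and the source may have more. Where it says the series, first, only, none or still open, it means among the compounds named here.

In a functional assay on WiDr cells (Homo sapiens) for antiproliferative activity (a lower number here means a stronger inhibitor of growth, a higher number a weaker inhibitor of growth), three compounds have been tested around the shared core of compound 2 `C[C@H]1CC(Cl)=C([Si](C)(C)C)[C@@H](C2CCCCC2)O1`, which gives 15000 nM. Compound 3 `C[C@H]1CC(Cl)=C[C@@H](C2CCCCC2)O1` gives 65000 nM. Compound 1 `CC(C)CC1C=C(Cl)CCO1` gives only a limit, > 100000 nM, and not a number. Among the two numbers shown, compound 2 stands lowest, its nearest neighbour being compound 3; the remaining value is the limit of > 100000 nM in this assay, at which 1 of the 3 values shown sits. Among the measured compounds shown here, the one measured step, a 4.3-fold higher number from compound 2 to compound 3 (0.64 log units; beyond the scatter), replaces the silyl group on the double-bonded ring carbon by hydrogen and weakens growth inhibition.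

Compound 4 `C[Si](C)(C)C1=C(Cl)C[C@H](Cc2ccccc2)O[C@@H]1C1CCCCC1` keeps the silyl group and cyclohexyl of compound 2 and differs from it by phenyl in place of hydrogen on a saturated chain carbon bound to a saturated ring carbon. For the measured compounds named here, no measured step touches this chain carbon: the step from compound 2 to compound 3 concerns the double-bonded ring carbon, and compound 1 differs from the others in more than one place, so its limit offers no guide to the benzyl change. The expectation for compound 4 can therefore rest only on the value of compound 2 15000 nM in this assay, with a broad allowance in either direction.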

Compound 4, concentration for 50% growth inhibition: 62000 nM
Compound 4: the middle estimate sits 6.2-fold (0.79 log units) below what was measured; measured number above the stated range.
By their numbers in this assay, from the lowest: compound 2; then compounds 4 and 3 (each within the scatter of the next). At a limit, above all of these: compound 1.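

In this assay, the saturated chain carbon bound to a saturated ring carbon proves not to be a silent position: the change from methyl to benzyl gives a 4.1-fold higher number from compound 2 to compound 4 (0.62 log units; beyond the scatter), so adding phenyl there weakens growth inhibition rather than strengthening it. Among the compounds shown here, the earlier compounds showed only a change on the double-bonded ring carbon, and this is the first measured step at this chain carbon, with the silyl group and cyclohexyl held as in compound 2. Compound 2 now has the lower number in both of its measured one-place steps, but nothing measured here accounts for the loss seen with phenyl.

The compounds shown leave open how the number changes along the series from methyl to benzyl, for example with an ethyl or a longer chain, and whether a cyclohexyl, a pyridine ring, an amine or a carboxylic acid at this chain carbon would behave as phenyl does. They also leave open whether benzyl at this place would have the same effect on the core of compound 3, where hydrogen stands in place of the silyl group.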